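Growing the Second Ester from Methyl to Isopropyl

The source may report more compounds than this note shows. Statements on the series, on what has been measured and on what is new or still open speak of the compounds shown alone.

Compound 2 `CCc1nc(Cl)c(C2C(C(=O)OC)=C(C)NC(C)=C2C(=O)OC(C)C)[nH]1` gives the higher of the two numbers in an assay on ileum for inhibition of Voltage-dependent L-type calcium channel subunit alpha-1C (Cavia porcellus) (a higher number here means a weaker inhibitor, a lower number a stronger inhibitor), namely 0.488 nM, while compound 1 `CCCOC(=O)C1=C(C)NC(C)=C(C(=O)OC)C1c1[nH]c(CC)nc1Cl` gives 0.146 nM. Within the data shown here, the one measured step, a 3.3-fold higher number from compound 1 to compound 2 (0.52 log units; beyond the scatter), concerns the other ester and does not bear directly on the present change. Compound 3 `CCc1nc(Cl)c(C2C(C(=O)OC(C)C)=C(C)NC(C)=C2C(=O)OC(C)C)[nH]1` differs from compound 2 by isopropyl in place of methyl on an oxygen next to a carbonyl group. Among the measured compounds shown here, with no step of this kind measured, only a small weakening is expected, a 1.6-fold higher number from compound 2 to compound 3 (0.21 log units; within the scatter), scarcely beyond the scatter. Compound 3 is therefore estimated at 0.8 nM, with a range from 0.25 nM to 2.5 nM.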

Compound 3, half-maximal inhibitory concentration: 0.748 nM
The estimate for compound 3 lay 1.1-fold (0.03 log units) above the measured number; measured number inside the range.
By their numbers in this assay, from the lowest: compound 1; then compounds 2 and 3 (each within the scatter of the next).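

Taking the methoxycarbonyl to isopropoxycarbonyl at this second ester gives a 1.5-fold higher number from compound 2 to compound 3 (0.19 log units; within the scatter) in this assay and so leaves the two compounds indistinguishable. Among these compounds, this is the first step read at this position, and it shows that isopropyl on an oxygen next to a carbonyl group can stand on both esters of the shared core without a change beyond the scatter. No measurement shown here explains this result.
On these data alone, whether a longer chain, such as butyl, or a benzyl group on this oxygen would also stay within the scatter remains open.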